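A few compounds are considered here, and "the series" means these few. Any claim that something is new, unique, unknown or untested is made for them only; others in the source may bear on it.

Compound 1 `Cc1nn(C)c(Oc2ccc(F)cc2)c1/C=N\CCCCCOc1cc2oc(=O)cc(C)c2cc1Cl`: in a functional assay on U-87MG ATCC cells for antiproliferative activity against U-87 MG (Homo sapiens), read by MTT assay, with a stated time of 72 h (a higher number here means a weaker inhibitor, a lower number a stronger inhibitor), compound 1 gives > 25000 nM, which is a limit of the assay rather than a number.
Compound 2 `Cc1nn(C)c(Oc2ccc(Cl)cc2)c1/C=N\CCCCCOc1cc2oc(=O)cc(C)c2cc1Cl`: in this assay compound 2 gives 18700 nM.
Compound 3 `Cc1nn(C)c(Oc2ccc(F)cc2)c1/C=N\CCCCCCOc1cc2oc(=O)cc(C)c2cc1Cl`: in this assay compound 3 gives 16700 nM.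

Of the two actual numbers, compound 3 and compound 2 sit within the scatter of each other, so neither can be called the stronger inhibitor. Compound 4 `Cc1nn(C)c(Oc2ccc(Cl)cc2)c1/C=N\CCCCCCOc1cc2oc(=O)cc(C)c2cc1Cl` differs from compound 3 by chloro in place of fluoro on an aromatic carbon. The same exchange has been measured once already, as an at least 1.3-fold lower number from compound 1 to compound 2 (0.12 log units; that floor lies within the scatter), a floor that lies within the scatter. The step from compound 3 to compound 4 is therefore expected to be small, as a 1.4-fold lower number from compound 3 to compound 4 (0.14 log units; within the scatter), and no change beyond the scatter is expected. Compound 4 is estimated at 12000 nM, within a range from 5000 nM to 25000 nM.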

Compound 4, half-maximal inhibitory concentration: 3850 nM
For compound 4 the middle estimate is 3.1-fold (0.49 log units) above the measured one; measured number outside the range, below it.
By their numbers in this assay, from the lowest: compound 4; then compounds 3 and 2 (each within the scatter of the next). At a limit, above all of these: compound 1.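

In this assay, within the data shown here, the exchange of fluoro for chloro on the aromatic carbon gives a 4.3-fold lower number from compound 3 to compound 4 (0.64 log units; beyond the scatter) and so, for the first time here, a step at this position that stands clear of the scatter. Compound 1 gives > 25000 nM as a limit of the assay and not a number. The earlier pair therefore set only a floor, and whether the change is worth the same on both cores stays undecided: the same change on two cores in this assay, an at least 1.3-fold lower number (0.12 log units; that floor lies within the scatter) from compound 1 to compound 2 and a 4.3-fold lower number (0.64 log units; beyond the scatter) from compound 3 to compound 4; the limit leaves it open whether they differ.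

Going by these compounds, whether bromo or methoxy at this position would lower the number further stays open. So does whether a longer chain would keep the gain seen with chloro.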